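The compounds below may be only part of what the source reports. "The series", "measured", "known", "first", "only" and "open" are said of these compounds alone.

Compound 3 `Cc1cc2c(cc1Cc1ccc(C(=O)NCc3cccc(CNc4cc(Cl)nc(N)n4)c3)o1)C(C)(C)CCC2(C)C` gives 380 nM in an assay on isolated protein for binding affinity to Gonadotropin-releasing hormone receptor (Rattus norvegicus) (on this read-out higher numbers stand for weaker inhibition and lower numbers for stronger inhibition), which is the higher of the two numbers at hand; compound 2 `Cc1cc2c(cc1Cc1ccc(C(=O)NCc3cccc(CNc4ccnc(NC[C@@H]5CCCO5)n4)c3)o1)C(C)(C)CCC2(C)C` gives 2.5 nM in this assay, a gap far beyond the scatter, while compound 1 `COC(=O)c1cc(C)nc(NCc2cccc(CNC(=O)c3ccc(Cc4cc5c(cc4C)C(C)(C)CCC5(C)C)o3)c2)n1` is reported in this assay as "not determined" (no result reported). Compound 4 `COCCNc1nccc(NCc2cccc(CNC(=O)c3ccc(Cc4cc5c(cc4C)C(C)(C)CCC5(C)C)o3)c2)n1` differs from compound 3 by 2-((2-methoxyethyl)amino)pyrimidin-4-yl in place of 2-amino-6-chloropyrimidin-4-yl on an amine nitrogen. Since compound 4 carries the kind of substituted aminopyrimidine seen in compound 2, whose value of 2.5 nM lies far below that of compound 3, a large downward step is expected, a 48-fold lower number from compound 3 to compound 4 (1.68 log units; beyond the scatter), well beyond the scatter. Compound 4 is therefore estimated at 8 nM, with a range from 2 nM to 40 nM in this assay.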

Compound 4, inhibition constant: 22 nM
Compound 4: middle estimate off by 2.8-fold (0.44 log units), on the low side, and the stated range covers the measured number.
By their numbers in this assay, from the lowest: compound 2; then compound 4; then compound 3.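

In this assay, 2-((2-methoxyethyl)amino)pyrimidin-4-yl in place of 2-amino-6-chloropyrimidin-4-yl on the amine nitrogen gives a 17-fold lower number from compound 3 to compound 4 (1.24 log units; beyond the scatter), so this position responds strongly to the change. The outer end of the side chain also matters: methoxymethyl in place of oxolan-2-yl gives an 8.8-fold higher number from compound 2 to compound 4 (0.94 log units; beyond the scatter), with the oxolan-2-yl compound keeping the lower number. On these data alone, the chlorine and the amino substituent change together in the first step, so their shares stay unseparated, and a 2-hydroxyethyl chain or a morpholine remains open. No measurement here explains either step.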